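This account rests on a few compounds, and the source may have more. Where it says the series, first, only, none or still open, it means among the compounds named here.

Measured compounds:
compound 1, `Cc1ccc(OCc2cn(Cc3ccc(Cl)cc3)nn2)cc1`, gives 17.3 ug/mL
compound 2, `Cc1ccc(OCc2cn(Cc3cccc(Cl)c3)nn2)cc1`, gives 16.3 ug/mL
compound 3, `Clc1ccc(Cn2cc(COc3c(Cl)cc(Cl)cc3Cl)nn2)cc1`, gives 27.2 ug/mL

All three numbers come from a physicochemical assay, read by spectrophotometry, with a stated time of 30 min; a higher number here means a weaker inhibitor, a lower number a stronger inhibitor. Compound 1 and compound 2 share one core and differ by 3-chlorophenyl in place of 4-chlorophenyl on a saturated chain carbon bound to an aromatic nitrogen. That change produces a 1.1-fold lower number from compound 1 to compound 2 (0.03 log units; within the scatter). Compound 3 is built on a second core; the difference between the core of compound 3 and the core of compound 1 is not broken down here. In this assay the number for compound 3 lies within the scatter of both compound 1 and compound 2, so no order among the three is read from these values.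

Compound 4, `Clc1cccc(Cn2cc(COc3c(Cl)cc(Cl)cc3Cl)nn2)c1`, has not been measured. It stands to compound 3 as compound 2 stands to compound 1: 3-chlorophenyl in place of 4-chlorophenyl on a saturated chain carbon bound to an aromatic nitrogen. The place of the change reads the same, word for word, in both pairs, so this is the same change carried onto the second core. For the measured compounds named here, the only measured instance of it is a 1.1-fold lower number from compound 1 to compound 2 (0.03 log units; within the scatter), and the expectation for compound 4 rests on that single step alone, with the change of core untested. On that basis the expected step is a 1.1-fold lower number from compound 3 to compound 4 (0.04 log units; within the scatter), again within the scatter. Compound 4 is therefore estimated at 25 ug/mL in this assay. For compound 4 the likely range is expected to run from 15 ug/mL to 45 ug/mL.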

Compound 4, half-maximal inhibitory concentration: 16.4 ug/mL
The estimate for compound 4 lay 1.5-fold (0.18 log units) above the measured number; measured number inside the range.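

In this assay, 3-chlorophenyl in place of 4-chlorophenyl on a saturated chain carbon bound to an aromatic nitrogen gives a 1.1-fold lower number from compound 1 to compound 2 (0.03 log units; within the scatter) on the core of compound 1 and a 1.7-fold lower number from compound 3 to compound 4 (0.22 log units; within the scatter) on the second core. For the compounds shown here, this shows only that the change, carried from one core to the other, stays within the scatter in both pairs; it does not show that the change lowers the number on either core, and with two pairs it does not establish that the cores respond alike or differently. The series data shown include no measurement that bears on the reason for either step.

The compounds shown carry only 4-chlorophenyl or 3-chlorophenyl at this place, so the response to a different group there, such as an amine, a carboxylic acid or a methoxy group in place of the chlorine, remains open. Also open, on these data alone, are a longer chain in place of the benzyl link and whether any such replacement would give a step beyond the scatter on either core.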